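The source may hold more compounds than are shown below. What is called first, only, known or untested is meant among the compounds shown, and "the series" means these compounds.

Compound 1, `CC(C)=CC[C@@H](OC(=O)c1ccoc1)C1=CC(=O)c2c(O)ccc(O)c2C1=O`, was tested in a functional assay on DU-145 cells (Homo sapiens) for cytotoxicity, read by MTT assay; a lower number here means a stronger inhibitor, a higher number a weaker inhibitor. In this assay compound 1 reached only the limit of > 100000 nM, so no number is known for it, only that it sits at that limit (the limit of > 100000 nM in this assay, at which 1 of the 3 values shown sits). Two measured relatives share its core. Compound 2, `CCC(C)(O)CC(=O)O[C@H](CC=C(C)C)C1=CC(=O)c2c(O)ccc(O)c2C1=O`, gives 16000 nM in this assay. Compound 3, `COC(C)CO[C@H](CC=C(C)C)C1=CC(=O)c2c(O)ccc(O)c2C1=O`, gives 16600 nM in this assay. The step of an at least 6.2-fold lower number from compound 1 to compound 2 (0.79 log units; beyond the scatter) and the step of an at least 6.0-fold lower number from compound 1 to compound 3 (0.77 log units; beyond the scatter) both point the same way: removing the (furan-3-yl)carbonyl group leads to a clearly lower number. The step of a 1.0-fold higher number from compound 2 to compound 3 (0.02 log units; within the scatter) shows that a 2-hydroxy-2-methylbutylcarbonyl group and a 2-methoxypropyl group cannot be told apart here.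

Compound 4, `CC(C)=CC[C@@H](OCC(C)O)C1=CC(=O)c2c(O)ccc(O)c2C1=O`, has not yet been measured. It differs from compound 1 in one place: 2-hydroxypropyl in place of (furan-3-yl)carbonyl on an oxygen on a saturated carbon. Compound 4 thus carries a short oxygen-bearing chain on the oxygen on the saturated carbon, as compound 3 does, so the steps to compound 2 and to compound 3 are the ones that bear on it, and both were at least modest drops. The step of an at least 5.5-fold lower number from compound 1 to compound 4 (0.74 log units; beyond the scatter) is therefore expected to be a drop beyond the scatter, of about the size seen for compound 3 with 16600 nM. Compound 4 is estimated to give 18000 nM in this assay, with a plausible range from 6000 nM to 60000 nM.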

Compound 4, half-maximal inhibitory concentration: 16100 nM
Beside the measured number, compound 4's estimate is 1.1-fold (0.05 log units) above it; measured number inside the range.
By their numbers in this assay, from the lowest: compounds 2, 4 and 3 (each within the scatter of the next). At a limit, above all of these: compound 1.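

Compound 4 brings a third kind of group to the oxygen on a saturated carbon, and an at least 6.2-fold lower number from compound 1 to compound 4 (0.79 log units; beyond the scatter) in this assay shows the same clear drop on leaving the (furan-3-yl)carbonyl group, so the drop now holds for all three replacements shown. The new compound also sharpens the picture among those replacements: putting hydrogen in place of methyl on an oxygen gives a 1.0-fold lower number from compound 3 to compound 4 (0.01 log units; within the scatter), and the 2-hydroxypropyl group set against the (2-hydroxy-2-methylbutyl)carbonyl group gives a 1.0-fold higher number from compound 2 to compound 4 (0.00 log units; within the scatter), so neither change can be told apart from repeat-measurement noise, and these chains appear interchangeable at this level of activity. Compound 1 itself gives only a limit, so the true size of every drop from it remains unknown: the limit of > 100000 nM in this assay, at which 1 of the 4 values shown sits.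

Going by these compounds, what an amine, a carboxylic acid or a longer chain would do in place of the 2-hydroxypropyl group stays open. It is equally unknown whether another ring on the carbonyl, such as a phenyl ring, would behave like the furan-3-yl group.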